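This account rests on a few compounds, and the source may have more. Where it says the series, first, only, none or still open, it means among the compounds named here.

Measured so far in a functional assay on HT-29 cells (Homo sapiens) for cytotoxicity, read by MTT assay, with a stated time of 72 h; on this read-out lower numbers stand for stronger inhibition of growth and higher numbers for weaker inhibition of growth:
compound 1 `CC(C)COC(=O)Nc1ccc([Se][Se]c2ccc(NC(=O)OCC(C)C)cc2)cc1`: 19900 nM
compound 2 `CC(C)COC(=O)Nc1ccc([Se]C#N)cc1`: 8100 nM
compound 3 `N#C[Se]c1ccc(NC(=O)OCc2ccc([N+](=O)[O-])cc2)cc1`: 22400 nM

Compound 2 holds the lowest of the three numbers in this assay. Its nearest neighbour is compound 1, whose number is higher by a margin beyond the usual scatter; compound 3 lies further off, also beyond the scatter. Within the data shown here, no pair among the three differs in a single place, so no single-change step is available, and the three values stand on their own.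

The next compound, compound 4 `CCOC(=O)Nc1ccc([Se]C#N)cc1`, keeps the core of compound 2 and changes only the chain on the oxygen next to the carbonyl group: methyl in place of isopropyl on a saturated chain carbon bound to an oxygen next to a carbonyl group. Cut one bond further out, this reads isobutyl to ethyl, or isobutoxy to ethoxy.

Nothing in the measured set isolates the effect of shortening this chain, so no shown step can anchor the expectation. The change is expected to be small in this assay, most likely none beyond the scatter, with a slight lean toward a higher number. The expected step is a 1.2-fold higher number from compound 2 to compound 4 (0.09 log units; within the scatter). Compound 4 is accordingly estimated at 10000 nM, with a range from 4000 nM to 25000 nM.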

Compound 4, concentration for 50% growth inhibition: 9300 nM
For compound 4 the middle estimate is 1.1-fold (0.03 log units) above the measured one; measured number inside the range.
By their numbers in this assay, from the lowest: compounds 2 and 4 (each within the scatter of the next); then compounds 1 and 3 (each within the scatter of the next).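

In this assay the series gains its first single-change comparison, and the step reads a 1.1-fold higher number from compound 2 to compound 4 (0.06 log units; within the scatter) with methyl in place of isopropyl on a saturated chain carbon bound to an oxygen next to a carbonyl group. At this place, then, isobutyl and ethyl cannot be told apart on this read-out, which the three earlier compounds could not show, since none of them differed from another in a single place. No measurement at hand speaks to the reason for this result.

From the compounds shown here alone, this single step covers only a narrow span of small saturated chains, so it remains open whether a longer chain such as hexyl, or a ring-bearing group such as plain benzyl, would give a number beyond the scatter at this place. Also open, going by these compounds, is whether a chain ending in an amine or a carboxylic acid would keep the number within the scatter of the ethyl and isobutyl compounds.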